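Swapping an Anilide Back to a Morpholine Amide

The compounds below may be only part of what the source reports. "The series", "measured", "known", "first", "only" and "open" are said of these compounds alone.

Measured so far in a functional assay on U-937 cells (Homo sapiens) for antiproliferative activity, read by MTT assay, with a stated time of 24 h (a lower number here means a stronger inhibitor, a higher number a weaker inhibitor), are three compounds:
compound 1 `CCCCc1oc2ccccc2c1C(=O)c1ccc(OCC(=O)N2CCOCC2)cc1` gives 45400 nM
compound 2 `CCCCc1oc2ccccc2c1C(=O)c1ccc(OCC(=O)Nc2ccccc2)cc1` gives 25900 nM
compound 3 `CCCCc1oc2ccccc2c1C(=O)c1ccc(OCC(=O)Nc2cccc(OC)c2)cc1` gives 24200 nM

Compound 3 at 24200 nM sits within the scatter of both other compounds, so the three cannot be ranked. Compound 4 `CCCCc1oc2ccccc2c1C(=O)c1ccc(OCCCC(=O)N2CCOCC2)cc1` comes next, and the change 2-((morpholin-4-yl)carbonyl)ethyl in place of (3-methoxyphenyl)carbamoyl on a saturated chain carbon bound to an oxygen on an aromatic ring puts 2-((morpholin-4-yl)carbonyl)ethyl in place of (3-methoxyphenyl)carbamoyl on a saturated chain carbon bound to an oxygen on an aromatic ring.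

Closest to this change is a 1.9-fold lower number from compound 1 to compound 3 (0.27 log units; within the scatter) with (3-methoxyphenyl)amino in place of morpholin-4-yl, which is the amide end of the present change read backwards. Also small are a 1.8-fold lower number from compound 1 to compound 2 (0.24 log units; within the scatter) and a 1.1-fold lower number from compound 2 to compound 3 (0.03 log units; within the scatter) in this short series. Among the measured compounds shown here, compound 1 with 45400 nM carries morpholin-4-yl as compound 4 does, but no measured compound carries the 2-((morpholin-4-yl)carbonyl)ethyl group, so that chain is untested.

A step beyond the scatter is therefore not expected in this assay here, only a slight drift toward the number of compound 1. The expected step is a 1.5-fold higher number from compound 3 to compound 4 (0.17 log units; within the scatter) by estimate. For compound 4 the estimated value is 36000 nM with an expected range from 18000 nM to 75000 nM once measured.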

Compound 4, half-maximal inhibitory concentration: 21400 nM
Compound 4: the middle estimate sits 1.7-fold (0.23 log units) above what was measured, within the range that was stated.
By their numbers in this assay, from the lowest: compounds 4, 3, 2 and 1 (each within the scatter of the next, the first and the last beyond it).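

In this assay, among the compounds shown here, the swap of (morpholin-4-yl)carbonyl for 2-((morpholin-4-yl)carbonyl)ethyl on a saturated chain carbon bound to an oxygen on an aromatic ring gives a 2.1-fold lower number from compound 1 to compound 4 (0.33 log units; beyond the scatter) as the first step beyond the scatter, though a modest one, so with the morpholine amide kept, the chain that carries it does register at this position. The anilides read differently: the same group gives a 1.1-fold lower number from compound 3 to compound 4 (0.05 log units; within the scatter) in place of (3-methoxyphenyl)carbamoyl and a 1.2-fold lower number from compound 2 to compound 4 (0.08 log units; within the scatter) in place of phenylcarbamoyl and both steps stay within the scatter, so compound 4 cannot be told apart from either anilide, even though it has no amide hydrogen. Nothing beyond these numbers is available to explain them.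

The compounds shown leave open whether a still longer chain ahead of the morpholine amide would carry the step further, and what an anilide would give on the chain of compound 4. They also leave open how a piperidine amide, or a free carboxylic acid at the chain end, would compare.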